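Chloro for methoxy on a thiosemicarbazone aryl group

The source may hold more compounds than are shown below. What is called first, only, known or untested is meant among the compounds shown, and "the series" means these compounds.

Compound 2 `COc1ccc(/C=N/NC(=S)NC(C)(C)[C@H]2CC=C(C)CC2)cc1` gives 70400 nM in a functional assay on UACC-62 cells (Homo sapiens) for inhibition, read by sulforhodamine B assay, with a stated time of 48 h (a lower number here means a stronger inhibitor of growth, a higher number a weaker inhibitor of growth), the only plain number among the three entries shown. Compound 3 `CC1=CC[C@H](C(C)(C)NC(=S)N/N=C/c2ccc(N(C)C)cc2)CC1` sits at the limit of > 100000 nM in this assay, at which 1 of the 3 values shown sits, so its entry > 100000 nM is a limit rather than a number. Compound 1 `CC1=CC[C@H](C(C)(C)NC(=S)NN)CC1` has "not determined" (no result reported) in this assay. Compound 4 `CC1=CC[C@H](C(C)(C)NC(=S)N/N=C/c2ccccc2Cl)CC1` differs from compound 2 by 2-chlorophenyl in place of 4-methoxyphenyl on a carbon with a double bond to nitrogen. Within the data shown here, the one measured step that alters the same aryl group, an at least 1.4-fold higher number from compound 2 to compound 3 (0.15 log units; that floor lies within the scatter), moves the number no further than the scatter allows to be seen. A change of comparable kind is therefore expected to leave compound 4 near compound 2, with a step of a 1.1-fold higher number from compound 2 to compound 4 (0.06 log units; within the scatter) that need not exceed the scatter. Compound 4 is estimated at 80000 nM, within 30000 nM to 200000 nM.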

Compound 4, concentration for total growth inhibition: 98000 nM
Compound 4: middle estimate off by 1.2-fold (0.09 log units), on the low side, and the stated range covers the measured number.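

In this assay this aryl position now has a step with a plain number at both ends, a 1.4-fold higher number from compound 2 to compound 4 (0.14 log units; within the scatter), where the earlier step gave only a floor. Thus 2-chlorophenyl in place of 4-methoxyphenyl, which swaps the oxygen for a chlorine, leaves the number inside the scatter. Compound 3 still stands as a limit and not a number: the limit of > 100000 nM in this assay, at which 1 of the 4 values shown sits.

The compounds shown leave open whether a carboxylic acid or a primary amine on this aryl group, or a longer alkyl chain in its place, would move the number beyond the scatter.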